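A few compounds are considered here, and "the series" means these few. Any claim that something is new, unique, unknown or untested is made for them only; others in the source may bear on it.

Measured in a functional assay on CCRF-CEM cells (Homo sapiens) for antiproliferative activity, read by cell counting, with a stated time of 2 days; on this read-out higher numbers stand for weaker inhibition and lower numbers for stronger inhibition:
compound 1 `COc1cc(C(=O)c2sc(Nc3ccccc3)nc2N)cc(OC)c1OC`: 9.4 nM
compound 2 `COc1ccc(C(=O)c2sc(Nc3ccccc3)nc2N)cc1OC`: 6900 nM
compound 3 `COc1ccc(Nc2nc(N)c(C(=O)c3ccc(Cl)cc3)s2)cc1`: 19 nM

Compound 1 has the lowest number of the three, compound 3 comes next, and compound 2 lies far off. Compound 4 `COc1ccc(Nc2nc(N)c(C(=O)c3cc(OC)c(OC)c(OC)c3)s2)cc1`, not yet measured, keeps the core of compound 1 and turns its anilino into (4-methoxyphenyl)amino: methoxy in place of hydrogen on an aromatic carbon. Within the data shown here, the only measured step, a 730-fold higher number from compound 1 to compound 2 (2.87 log units; beyond the scatter), is large, but it concerns a methoxy at another place in the molecule, so it gives no direct measure of this change. It does show that a single methoxy can matter greatly in this series. More to the point, compound 3 already carries the (4-methoxyphenyl)amino group and gives 19 nM, though its other half differs. A small move towards a higher number is therefore expected in this assay, possibly none beyond the scatter. The expected change is a 1.6-fold higher number from compound 1 to compound 4 (0.20 log units; within the scatter). For compound 4 the estimated value is 15 nM. The expected range for compound 4 runs from 3 nM to 70 nM.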

Compound 4, half-maximal inhibitory concentration: 1100 nM
For compound 4 the middle estimate is 73-fold (1.87 log units) below the measured one; measured number above the stated range.
By their numbers in this assay, from the lowest: compound 1; then compound 3; then compound 4; then compound 2.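

In this assay, the step of a 120-fold higher number from compound 1 to compound 4 (2.07 log units; beyond the scatter) shows that on the core of compound 1 this position does not accept a methoxy in place of hydrogen without a large rise in the number. The earlier step of a 730-fold higher number from compound 1 to compound 2 (2.87 log units; beyond the scatter) concerned only a methoxy elsewhere in the molecule, where removing the group raised the number. Now a methoxy added on the anilino ring, para to a large group, raises it as well, so large steps arise at two separate places in the molecule, in opposite directions of change. Nothing shown gives a measured account of this rise.

The compounds shown leave open whether a fluorine, a methyl or an amine at this same place would give a similar rise. They also leave open whether a hydroxy or a longer chain such as ethoxy would behave as the methoxy does.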